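The source may hold more compounds than are shown below. What is called first, only, known or untested is meant among the compounds shown, and "the series" means these compounds.

The measured compounds, each with its value in an assay on CHO cells for displacement of a labelled ligand from prostaglandin E2 receptor EP3 subtype (Homo sapiens), read by radioligand binding; a higher number here means a weaker inhibitor, a lower number a stronger inhibitor:

Compound 1, `CC(C)C(O)(C(=O)O)c1ccc(-c2ccc3ccccc3c2)[nH]c1=O`, gives 544 nM.
Compound 2, `CC(C)C(Cc1nnc[nH]1)c1ccc(-c2ccc3cccc(F)c3c2)[nH]c1=O`, gives 10 nM.
Compound 3, `CCn1ncc2c(F)cc(-c3ccc(C(CC)(CC)c4nncn4C)c(=O)[nH]3)cc21`, gives 54 nM.

Compound 2 stands lowest of the three, and its gaps to compound 3 and to compound 1 both lie beyond the scatter of repeated measurements, so it is the strongest inhibitor of the measured set. Compound 1, which carries a hydroxyl and a carboxylic acid on the same chain carbon and lacks the fluorine on its bicyclic ring, gives the weakest result.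

Compound 4, `CC(C)C(c1ccc(-c2ccc3cccc(F)c3c2)[nH]c1=O)N1CCNC1=O`, has not yet been measured. Its difference from compound 2 is 2-oxoimidazolidin-1-yl in place of (4H-1,2,4-triazol-3-yl)methyl on a saturated chain carbon bound to an aromatic carbon and a saturated chain carbon. The aromatic ring with three nitrogens is thus replaced by a saturated ring of the same size that keeps one hydrogen-bond donor and offers a carbonyl as acceptor. For the measured compounds named here, no measured pair here shows such a change, so its effect can only be guessed. Compound 4 is expected to lose some potency, with a step of a 3.0-fold higher number from compound 2 to compound 4 (0.48 log units; beyond the scatter), as the triazole of compound 2 is linked to the lowest number seen. Compound 4 is estimated at 30 nM, within a range from 8 nM to 120 nM.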

Compound 4, inhibition constant: 9.1 nM
The estimate for compound 4 lay 3.3-fold (0.52 log units) above the measured number; low and high end bracket the measured number.
By their numbers in this assay, from the lowest: compounds 4 and 2 (each within the scatter of the next); then compound 3; then compound 1.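

In this assay, placing 2-oxoimidazolidin-1-yl where (4H-1,2,4-triazol-3-yl)methyl stood on the saturated chain carbon gives a 1.1-fold lower number from compound 2 to compound 4 (0.04 log units; within the scatter) and so leaves the number unmoved within the scatter. This is the only pair shown that differs in one place, and it shows that, on this core, a five-membered aromatic ring with 3 hetero atoms is not needed on this carbon to keep a number at this level, since a five-membered non-aromatic ring with 2 hetero atoms does as well. No measurement shown explains why the two groups match.

Going by these compounds, it remains open whether other groups on this carbon, such as a piperidine ring or an open-chain amide, would also match. On these data alone, it is equally open whether the match would hold on the core of compound 3.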